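Methoxy on the Phenyl Ring of a Benzimidazole Amide

This account rests on a few compounds, and the source may have more. Where it says the series, first, only, none or still open, it means among the compounds named here.

Of the compounds shown here, two sharing one core have been measured. Compound 1 `O=C(CN1CCN(c2ccccc2)CC1)Nc1nc2ccccc2[nH]1` carries a phenyl group on a ring nitrogen; in a functional assay, read by spectrophotometry, with a stated time of 30 min (a lower number here means a stronger inhibitor, a higher number a weaker inhibitor), compound 1 gives 166 ug/mL. Compound 2 `O=C(CN1CCN(c2ncccn2)CC1)Nc1nc2ccccc2[nH]1` replaces that phenyl with a pyrimidin-2-yl group, and in this assay compound 2 gives 108 ug/mL. Compound 1 therefore stands as the higher of the two numbers, but the difference is small: a 1.5-fold lower number from compound 1 to compound 2 (0.19 log units; within the scatter).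

Compound 3 `COc1ccccc1N1CCN(CC(=O)Nc2nc3ccccc3[nH]2)CC1` is the next compound, not yet measured. It differs from compound 1 in one place: methoxy in place of hydrogen on an aromatic carbon. Within the data shown here, no measured step touches this exact change; the only step available, a 1.5-fold lower number from compound 1 to compound 2 (0.19 log units; within the scatter), concerns swapping the whole phenyl for another ring and stayed within the scatter. There is thus no evidence in these two compounds that a small change on the phenyl ring moves the number far in either direction, so the expectation is a step from compound 1 to compound 3 no larger than the scatter, a 1.1-fold lower number from compound 1 to compound 3 (0.04 log units; within the scatter). On that basis compound 3 is estimated to give about 150 ug/mL in this assay, with a plausible range from 60 ug/mL to 400 ug/mL.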

Compound 3, half-maximal inhibitory concentration: 133 ug/mL
For compound 3 the middle estimate is 1.1-fold (0.05 log units) above the measured one; the measured number falls inside the stated range.
By their numbers in this assay, from the lowest: compounds 2, 3 and 1 (each within the scatter of the next).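

Unlike the pair before it, which swapped one whole ring for another, compound 3 tests a group added to the phenyl ring itself: in this assay, methoxy on an aromatic carbon, ortho to a large group, gives a small step (a 1.2-fold lower number from compound 1 to compound 3 (0.10 log units; within the scatter)). Compared with the pyrimidin-2-yl group of compound 2, the 2-methoxyphenyl group of compound 3 also gives a small step (a 1.2-fold higher number from compound 2 to compound 3 (0.09 log units; within the scatter)), so all three groups on this ring nitrogen lie within the scatter of one another. No other measurement shown here offers an explanation for how little these changes register.

From the compounds shown here alone, whether other groups at this place, such as a chlorine atom, an amine or a carboxylic acid, would also stay within the scatter remains open, as does the effect of methoxy on other carbons of the phenyl ring. The amide link stays the same in all three compounds, so it is also unknown whether a longer chain there would shift the number in this assay.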